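Swapping Fluoro for Nitro on a Weakly Active Core

The compounds below may be only part of what the source reports. "The series", "measured", "known", "first", "only" and "open" are said of these compounds alone.

Compound 1 `CCn1c(/C=C2/C(=O)Nc3ccc(F)cc32)nc2ccccc21` is one of three related compounds tested in a functional assay on PC-3 cells (Homo sapiens) for cytotoxicity, read by MTT assay, with a stated time of 48 h; a lower number here means a stronger inhibitor, a higher number a weaker inhibitor. In this assay compound 1 reaches only > 50000 nM, which is a limit of the assay and not a number. Compound 2 `Cn1c(/C=C2/C(=O)Nc3ccc(Br)cc32)nc2ccccc21` likewise stops at the limit > 50000 nM. Within the data shown here, compound 3 `Cn1c(/C=C2/C(=O)Nc3ccc(F)cc32)nc2ccccc21` is the only one with a number, giving 34300 nM. The two measured steps are an at least 1.4-fold lower number from compound 1 to compound 3 (0.16 log units; that floor lies within the scatter) and an at least 1.4-fold lower number from compound 2 to compound 3 (0.16 log units; that floor lies within the scatter); both stay within the scatter, and the values gather at the limit of > 50000 nM in this assay, at which 2 of the 3 values shown sit. Compound 4 `CCn1c(/C=C2/C(=O)Nc3ccc([N+](=O)[O-])cc32)nc2ccccc21` differs from compound 1 by nitro in place of fluoro on an aromatic carbon. Only the halogen exchange between compound 2 and compound 3 touches this position, and it lay within the scatter. Compound 4 is therefore expected to show no step beyond the scatter, a number no higher from compound 1 to compound 4 (the limit leaves the size open), with an estimated 50000 nM between 20000 nM and 200000 nM.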

Compound 4, half-maximal inhibitory concentration: 40100 nM
Estimate against measurement, compound 4: 1.2-fold (0.10 log units) above, within the range that was stated.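

Nitro, with more heavy atoms than fluoro and with hydrogen-bond acceptors that fluoro lacks, can sit on this aromatic carbon without a step beyond the scatter in this assay. The earlier exchange at this place was only between two halogens, whereas this change of a different kind gives an at least 1.2-fold lower number from compound 1 to compound 4 (0.09 log units; that floor lies within the scatter). The values still gather at one end of the scale: the limit of > 50000 nM in this assay, at which 2 of the 4 values shown sit.

From the compounds shown here alone, whether an amine or a carboxylic acid here would move the number beyond the scatter remains open. So does the effect of a longer chain on the aromatic nitrogen.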